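A few compounds are considered here, and "the series" means these few. Any claim that something is new, unique, unknown or untested is made for them only; others in the source may bear on it.

Compound 1: `Cc1ccccc1-c1cc(C#Cc2ccc(CCC(=O)O)cc2)ccn1`, 92%
Compound 2: `O=C(O)CCc1ccc(C#Cc2cccs2)cc1`, 97%

Both compounds were tested in an in vitro functional assay on 1321-N1 cells for agonist activity at Free fatty acid receptor 1 (Homo sapiens), read by fluorescence, spectrophotometry and calcium flux; a higher number here means a larger maximal response, a lower number a smaller maximal response. Compound 1 gives 92%, and compound 2 gives 97% in this assay. These two numbers lie within the usual scatter of each other, so neither compound can be said to reach a larger maximal response than the other. Compound 3, `O=C(O)CCc1ccc(C#Cc2cccnc2)cc1`, has not yet been measured. It differs from compound 2 in one place: pyridin-3-yl in place of thiophen-2-yl on a triple-bonded carbon. Both the group that leaves and the group that enters are single aromatic rings with one hetero atom and one hydrogen-bond acceptor. Within the data shown here, no measured pair here shows what such a swap does, but compound 1, with a different group on the same triple-bonded carbon, gives 92%, so the expected step of a number 7 percentage points lower from compound 2 to compound 3 (within the scatter) is small and within the scatter. Compound 3 is therefore estimated at 90% in this assay, with a range from 70% to 105%.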

Compound 3, largest response reached (reported as efficacy), in percent of the reference or control that the assay uses: 96%
Estimate against measurement, compound 3: 6 percentage points below, within the range that was stated.
By their numbers in this assay, from the lowest: compounds 1, 3 and 2 (each within the scatter of the next).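

Pyridin-3-yl in place of thiophen-2-yl on a triple-bonded carbon gives a number 1 percentage points lower from compound 2 to compound 3 (within the scatter) in this assay and provides the first measured pair that differs in one place. At this position, a five-membered aromatic ring with sulfur and a six-membered aromatic ring with nitrogen therefore cannot be told apart by their largest response, although this read-out does not show how much compound is needed to reach it. Nothing measured here explains why the two rings give such similar numbers.

The compounds shown leave open whether a plain phenyl ring or a ring-free group, such as a short chain ending in an amine, would give a similar response on the same carbon. They also leave open how an amide in place of the carboxylic acid would change the response.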